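Thiophene for Chlorophenyl on a Homologated Boronic Acid

The source may report more compounds than this note shows. Statements on the series, on what has been measured and on what is new or still open speak of the compounds shown alone.

Three boronic acids share a naphthol sulfonamide core. Compound 1 `CC(C)C[C@H](NC(=O)CSc1cc(NS(=O)(=O)c2ccc(Cl)cc2)c2ccccc2c1O)B(O)O` gives 10400 nM in a functional assay on MCF7 cells (Homo sapiens) for antiproliferative activity, read by sulforhodamine B assay, with a stated time of 72 h; a lower number here means a stronger inhibitor, a higher number a weaker inhibitor. Compound 2 `CC(C)C[C@H](NC(=O)CSc1cc(NS(=O)(=O)c2cccs2)c2ccccc2c1O)B(O)O` gives 9450 nM in this assay; the change between them is thiophen-2-yl in place of 4-chlorophenyl on a sulfonyl sulfur, and it produced a 1.1-fold lower number from compound 1 to compound 2 (0.04 log units; within the scatter). Compound 3 `CC(C)C[C@H](NC(=O)CCSc1cc(NS(=O)(=O)c2ccc(Cl)cc2)c2ccccc2c1O)B(O)O` gives 6910 nM in this assay; its core differs from that of compound 1 by a group of 12 heavy atoms (7 carbon, 1 boron, 1 nitrogen, 3 oxygen; no ring) in place of a group of 11 heavy atoms (6 carbon, 1 boron, 1 nitrogen, 3 oxygen; no ring), on a saturated chain carbon bound to a sulfur, and this gave a 1.5-fold lower number from compound 1 to compound 3 (0.18 log units; within the scatter).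

Compound 4 `CC(C)C[C@H](NC(=O)CCSc1cc(NS(=O)(=O)c2cccs2)c2ccccc2c1O)B(O)O` is not yet measured. It differs from compound 3 by thiophen-2-yl in place of 4-chlorophenyl on a sulfonyl sulfur, the same change already seen between compound 1 and compound 2, at the same place. The expected step is a 1.1-fold lower number from compound 3 to compound 4 (0.04 log units; within the scatter), because a 1.1-fold lower number from compound 1 to compound 2 (0.04 log units; within the scatter). Compound 4 is therefore estimated at 6300 nM in this assay, with a likely range from 3000 nM to 13000 nM.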

Compound 4, half-maximal inhibitory concentration: 6470 nM
Compound 4: the middle estimate sits 1.0-fold (0.01 log units) below what was measured; low and high end bracket the measured number.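

On the second core, thiophen-2-yl in place of 4-chlorophenyl on a sulfonyl sulfur gave a 1.1-fold lower number from compound 3 to compound 4 (0.03 log units; within the scatter) in this assay. Going by these compounds alone, the change behaved alike on the two cores: the same change on two cores in this assay, a 1.1-fold lower number (0.04 log units; within the scatter) from compound 1 to compound 2 and a 1.1-fold lower number (0.03 log units; within the scatter) from compound 3 to compound 4, 1.0-fold (0.01 log units) apart, within the scatter of two such steps Both steps lie within the scatter, so this shows only that the swap left the number unchanged on these two cores; it does not show that a real effect carries over, and two cores say nothing about others.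

On these data alone, it remains open whether another group on the sulfonyl sulfur, such as a phenyl ring carrying an amine or a carboxylic acid, would move the number beyond the scatter. As far as these compounds go, a longer chain than that of compound 3 is likewise open.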